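Methoxy for chloro on the pyrazole-bound phenyl of compound 1

This account rests on a few compounds, and the source may have more. Where it says the series, first, only, none or still open, it means among the compounds named here.

Measured so far in a functional assay on MCF7 cells (Homo sapiens) for antiproliferative activity, read by sulforhodamine B assay, with a stated time of 48 h; on this read-out lower numbers stand for stronger inhibition of growth and higher numbers for weaker inhibition of growth: compound 1 `COc1ccc(Cn2cc(CNC(=O)c3cn(-c4ccccc4)nc3-c3ccc(Cl)cc3)nn2)cc1` gives 8000 nM; compound 3 `COc1cc(Cn2cc(CNC(=O)c3cn(-c4ccccc4)nc3-c3ccc(Cl)cc3)nn2)cc(OC)c1` gives 150 nM. Compound 2 `COc1ccc(Cn2cc(CNC(=O)c3cn(-c4ccccc4)nc3-c3ccc(Cl)cc3)nn2)cc1OC` reaches only the limit > 100000 nM, which is a bound of the assay and not a number.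

Among the two numbers, compound 1 stands highest, with compound 3 nearest through a 53-fold lower number from compound 1 to compound 3 (1.73 log units; beyond the scatter). Compound 4 `COc1ccc(Cn2cc(CNC(=O)c3cn(-c4ccccc4)nc3-c3ccc(OC)cc3)nn2)cc1` differs from compound 1 by methoxy in place of chloro on an aromatic carbon. The measured steps of an at least 12-fold higher number from compound 1 to compound 2 (1.09 log units; beyond the scatter) and an at least 660-fold lower number from compound 2 to compound 3 (2.82 log units; beyond the scatter) all change the benzyl ring, not the phenyl on the shared core, so none of them bears on this step. With no guide, compound 4 is expected to show a step of a 1.3-fold higher number from compound 1 to compound 4 (0.10 log units; within the scatter) within the scatter, estimated at 10000 nM (range 2500 nM to 40000 nM).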

Compound 4, concentration for 50% growth inhibition: 22900 nM
Compound 4: middle estimate off by 2.3-fold (0.36 log units), on the low side; measured number inside the range.
By their numbers in this assay, from the lowest: compound 3; then compound 1; then compound 4. At a limit, above all of these: compound 2.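

Among the compounds shown here, the phenyl on the shared core, unchanged in the earlier steps, also responds to substitution: methoxy in place of chloro gives a 2.9-fold higher number from compound 1 to compound 4 (0.46 log units; beyond the scatter) and so weakens growth inhibition. At this place, para to a large group, the change is modest beside the large steps on the benzyl ring. Nothing in the data shown accounts for this shift. Going by these compounds, what stays open is whether fluoro or an amine at this place would match chloro, and whether methoxy here costs as much alongside the 3,5-dimethoxyphenyl of compound 3.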